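A few compounds are considered here, and "the series" means these few. Any claim that something is new, unique, unknown or untested is made for them only; others in the source may bear on it.

Working notes on the series. Compound 1 `C[C@H](NC(=O)c1ccc(C#Cc2cccc(F)c2)cn1)C(C)(C)C` is measured in a functional assay on HEK293 cells for positive allosteric modulation of metabotropic glutamate receptor 5 (Rattus norvegicus), read by fluorescence and calcium flux; a higher number here means a larger maximal response, a lower number a smaller maximal response; compound 1 gives 70.8%. Compound 2 `CC(C)(C)CNC(=O)c1ccc(C#Cc2cccc(F)c2)cn1` carries the change hydrogen in place of methyl on a saturated chain carbon bound to an amide-type nitrogen and a saturated chain carbon relative to compound 1, and in this assay compound 2 gives 63.9%, a step of a number 6.9 percentage points lower from compound 1 to compound 2 (within the scatter). Compound 3 `C[C@@H](NC(=O)c1ccc(C#Cc2ccccn2)cn1)C(C)(C)C` has a different core from compound 1; the difference between the two cores is not broken down here. In this assay compound 3 gives 63%, and the values of compound 2 and compound 3 fall within the usual scatter of each other.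

Compound 4 `CC(C)[C@@H](C)NC(=O)c1ccc(C#Cc2ccccn2)cn1`, not yet measured, derives from compound 3 by hydrogen in place of methyl on a saturated chain carbon bound to three saturated chain carbons. This is the same kind of change as that from compound 1 to compound 2, although the place differs: there the methyl sat on a saturated chain carbon bound to an amide-type nitrogen and a saturated chain carbon, here on a saturated chain carbon bound to three saturated chain carbons. Because the earlier step of a number 6.9 percentage points lower from compound 1 to compound 2 (within the scatter) stayed small, a step of about a number 4 percentage points lower from compound 3 to compound 4 (within the scatter) is expected from compound 3 to compound 4. Compound 4 is therefore estimated to give 59% in this assay, between 45% and 74%.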

Compound 4, largest response reached (reported as efficacy), in percent of the reference or control that the assay uses: 58.5%
Compound 4: the middle estimate sits 0.5 percentage points above what was measured; low and high end bracket the measured number.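

In this assay the new step reads a number 4.5 percentage points lower from compound 3 to compound 4 (within the scatter), and set beside the earlier one it shows no difference that can be told from the scatter: the same change on two cores in this assay, a number 6.9 percentage points lower (within the scatter) from compound 1 to compound 2 and a number 4.5 percentage points lower (within the scatter) from compound 3 to compound 4, 2.4 percentage points apart, within the scatter of two such steps. On these two pairs, hydrogen in place of methyl therefore carries from one core to the other with a step of comparable size in the largest response reached. This does not show that the change is without effect or that it would behave alike on further cores, since it rests on two pairs only and the methyl leaves a different place in each, once from a saturated chain carbon bound to an amide-type nitrogen and a saturated chain carbon, once from a saturated chain carbon bound to three saturated chain carbons.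

Open, from the compounds shown here alone, is how the response behaves when the isopropyl end of compound 4 gives way to a longer chain or to a chain bearing an amine or a carboxylic acid. Also open, going by these compounds, is whether the step stays this small on a third core.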